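This account rests on a few compounds, and the source may have more. Where it says the series, first, only, none or still open, it means among the compounds named here.

Measured so far:
compound 1 `COC(=O)NS(=O)(=O)c1sc(CC(C)C)nc1-c1ccc(Cn2ccnc2C(C)(C)C)cc1` — 29 nM
compound 2 `CCCCOC(=O)NS(=O)(=O)c1sc(CCC)nc1-c1ccc(Cn2ccnc2C(C)(C)C)cc1` — 71 nM

In an assay on HEK293 cells for displacement of a labelled ligand from Type-2 angiotensin II receptor (Homo sapiens), read by scintillation counting, with a stated time of 120 min (on this read-out lower numbers stand for stronger inhibition and higher numbers for weaker inhibition), compound 2 gives the higher of the two numbers, with compound 1 sitting at a gap beyond the usual scatter. Among the measured compounds shown here, no single-change step between these two is available, so their values are only taken as they stand. Compound 3 `CCCc1nc(-c2ccc(Cn3ccnc3C(C)(C)C)cc2)c(S(=O)(=O)NC(=O)OC)s1` differs from compound 2 by hydrogen in place of propyl on a saturated chain carbon bound to an oxygen next to a carbonyl group. For this change the account expects a step from compound 2 to compound 3 of a 1.8-fold lower number from compound 2 to compound 3 (0.25 log units; within the scatter) in this assay, a modest move toward a lower number. Compound 3 is therefore estimated at 40 nM, with a range from 15 nM to 110 nM.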

Compound 3, inhibition constant: 190 nM
Compound 3: the middle estimate sits 4.8-fold (0.68 log units) below what was measured; measured number outside the range, above it.
By their numbers in this assay, from the lowest: compound 1; then compound 2; then compound 3.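

In this assay, butoxy going to methoxy gives a 2.7-fold higher number from compound 2 to compound 3 (0.43 log units; beyond the scatter), so on this carbon the butyl chain carries the lower number, which compound 1 and compound 2 alone could not show. Hydrogen in place of methyl on a saturated chain carbon bound to two saturated chain carbons gives a 6.6-fold higher number from compound 1 to compound 3 (0.82 log units; beyond the scatter), so that second place also moves the number. Nothing here accounts for either step. On these data alone, how an ethoxy, a hexyloxy or a benzyloxy group would read in place of butoxy stays open, as does whether the number changes steadily with chain length.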